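Removing an acetoxy group from a cytotoxicity series

A few compounds are considered here, and "the series" means these few. Any claim that something is new, unique, unknown or untested is made for them only; others in the source may bear on it.

Measured compounds:
- compound 1, `O=C1N/C(=N/N=C/c2c(-c3ccc(Br)cc3)[nH]c3ccccc23)SC1CCO`: 29200 nM
- compound 2, `CC(=O)OCCC1S/C(=N\N=C\c2c(-c3ccccc3)[nH]c3ccccc23)NC1=O`: 37100 nM
- compound 3, `C=CCSc1nn2c(C=O)c(-c3ccccc3)nc2s1`: > 50000 nM

In an ADME assay on BJ cells (Homo sapiens) for cytotoxicity, read by fluorescence, with a stated time of 24 h (on this read-out lower numbers stand for stronger inhibition and higher numbers for weaker inhibition), compound 2 gives 37100 nM. This is the higher of the two numbers measured, but its neighbour compound 1, at 29200 nM, lies within the usual scatter of it, so the two cannot be told apart. Compound 3 is a different case: its result is a limit of the assay, not a number, as the limit of > 50000 nM in this assay, at which 1 of the 3 values shown sits, shows.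

Compound 4, `CCC1S/C(=N\N=C\c2c(-c3ccccc3)[nH]c3ccccc23)NC1=O`, is not yet measured. It differs from compound 2 in one place:

hydrogen in place of acetoxy on a saturated chain carbon, two bonds along the chain from a saturated ring carbon

Going by the values given here, no pair of measured compounds differing in a single place is available, so the size of this step is not known from data. Given that compound 1 and compound 2 already sit close together in this assay despite differing at several places, the step from compound 2 to compound 4 is expected to stay within the scatter, as a 1.0-fold lower number from compound 2 to compound 4 (0.01 log units; within the scatter). Compound 4 is therefore estimated at 36000 nM, with a range from 15000 nM to 80000 nM.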

Compound 4, half-maximal inhibitory concentration: > 50000 nM
Compound 4 ended at the assay's limit; the forecaster's own chance of this, stated with the estimate: 30%; middle value at least 1.3-fold (0.14 log units) from the limit.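

In this assay, going by these compounds alone, this is the first step at this position that can be read: replacing acetoxy with hydrogen, so that 2-acetoxyethyl becomes ethyl, gives an at least 1.3-fold higher number from compound 2 to compound 4 (0.12 log units; that floor lies within the scatter). Compound 4 gives > 50000 nM, which is a limit of the assay and not a number. The change therefore brings no stronger inhibition of these cells, yet how far the number rises cannot be read because the result of compound 4 stops at a limit: the limit of > 50000 nM in this assay, at which 2 of the 4 values shown sit.

The compounds shown leave open what an amine, a carboxylic acid or a longer chain would do at this position. On these data alone, compound 1 carries a free hydroxyl on its chain but differs from compound 2 in more than one place, so the effect of that hydroxyl alone also remains open.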